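The compounds below may be only part of what the source reports. "The series", "measured", "known", "first", "only" and "open" are said of these compounds alone.

Working notes on the series. Three compounds of the shared core carry a number in a functional assay on KM12 cells (Homo sapiens) for inhibition, read by sulforhodamine B assay, with a stated time of 48 h (a lower number here means a stronger inhibitor of growth, a higher number a weaker inhibitor of growth), so far. Compound 1 `Nc1cc(N)c2nc(-c3ccccc3)c(Oc3ccc(Cl)c(Cl)c3)nc2c1` gives 6310 nM in this assay. Compound 2 `COc1cc(CNc2nc3cc(N)cc(N)c3nc2-c2ccccc2)cc(OC)c1OC` gives 479 nM, a lower number than compound 1 by a gap beyond the scatter. Compound 3 `CCOC(=O)[C@H](CCC(=O)O)NC(=O)c1ccc(Oc2nc3cc(N)cc(N)c3nc2-c2ccccc2)cc1` gives 27500 nM, a higher number than compound 1, again beyond the scatter. Compound 1 therefore holds the second highest number of the three, with compound 3 nearest and compound 2 furthest from it.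

The next step goes from compound 1 to compound 4 `Nc1cc(N)c2nc(-c3ccccc3)c(Sc3ccc(F)cc3)nc2c1`. The change is (4-fluorophenyl)sulfanyl in place of 3,4-dichlorophenoxy on an aromatic carbon. Within the data shown here, no pair of measured compounds differs in only this place, so there is no measured step to set the size against; the two halogenated aryl substituents here are exchanged for one another at the same position of the core, and nothing among compounds 1, 2 and 3 separates the effect of the sulfur link from that of the halogen pattern.

The expectation for compound 4 is a number close to that of compound 1, with the step from compound 1 to compound 4 estimated as a 1.3-fold lower number from compound 1 to compound 4 (0.10 log units; within the scatter), not clearly beyond the scatter in either direction. Compound 4 is estimated at 5000 nM in this assay, within a range from 1500 nM to 16000 nM.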

Compound 4, concentration for 50% growth inhibition: 20900 nM
Estimate against measurement, compound 4: 4.2-fold (0.62 log units) below, and the stated range ends below it.
By their numbers in this assay, from the lowest: compound 2; then compound 1; then compounds 4 and 3 (each within the scatter of the next).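

In this assay, among these compounds, the exchange at this aromatic carbon next to the ring nitrogen gives a 3.3-fold higher number from compound 1 to compound 4 (0.52 log units; beyond the scatter) and so supplies the first measured step at this position. The position is therefore not indifferent to which aryl substituent it carries, although the step is modest in size. Link atom and halogen pattern change together in this single step, so the step belongs to the exchange as a whole and to neither part alone, and nothing at hand bears on the reason for it.

Whether the sulfur link or the halogen pattern accounts for the step remains open, and 4-fluorophenoxy or (3,4-dichlorophenyl)sulfanyl at this carbon would separate the two. On these data alone, how an unsubstituted phenoxy group or a morpholine at the same carbon would read in this assay also remains open.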